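Aryl amine exchange from compound 1 to compound 3

The source may hold more compounds than are shown below. What is called first, only, known or untested is meant among the compounds shown, and "the series" means these compounds.

Values measured in a functional assay on MGC-803 cells (Homo sapiens) for inhibition, read by sulforhodamine B assay (a lower number here means a stronger inhibitor, a higher number a weaker inhibitor), are as follows.

Compound 1 `O=C1C=C(Nc2ccccc2F)C(=O)c2c1nc1n2[C@H]2OC[C@@H](O)[C@H]2OC1` gives 2080 nM
Compound 2 `O=C1C(Nc2ccc(C(F)(F)F)cc2)=CC(=O)c2c1nc1n2[C@H]2OC[C@@H](O)[C@H]2OC1` gives 1860 nM

Compound 1 and compound 2 lie within the scatter of each other, so compound 1 holds no separate place on these numbers. The two values mark a single level.

Compound 3 `O=C1C=C(Nc2ccc(C(F)(F)F)cc2)C(=O)c2c1nc1n2[C@H]2OC[C@@H](O)[C@H]2OC1` keeps the core of compound 1 and changes one group. The counted difference is 4-(trifluoromethyl)phenyl in place of 2-fluorophenyl on an amine nitrogen and the exchange places 4-(trifluoromethyl)phenyl in place of 2-fluorophenyl on an amine nitrogen.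

Going by the values given here, no step between two measured compounds that differ in one place is available, so this exchange has no direct measure. Among the compounds with values here, the only guide is the level set by compound 1 at 2080 nM and compound 2 at 1860 nM in this series. In this assay no step beyond the scatter is expected, in either direction. The estimated change is a 1.1-fold lower number from compound 1 to compound 3 (0.04 log units; within the scatter) and is expected to stay inside the scatter. For compound 3 the expected value is 1900 nM with an estimated range from 800 nM to 4500 nM and a wide margin on both sides.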

Compound 3, half-maximal inhibitory concentration: 2820 nM
Beside the measured number, compound 3's estimate is 1.5-fold (0.17 log units) below it; the range from low to high includes it.
By their numbers in this assay, from the lowest: compounds 2, 1 and 3 (each within the scatter of the next).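

In this assay, going by these compounds alone, the exchange of 2-fluorophenyl for 4-(trifluoromethyl)phenyl on the amine nitrogen gives the first direct step at this position: a 1.4-fold higher number from compound 1 to compound 3 (0.13 log units; within the scatter) is all that separates the pair. The entering group has 10 heavy atoms against 7 for the leaving group, and it carries three fluorines rather than one, yet this pair does not separate the two aryl groups on these numbers. The change in group is therefore compatible with holding the level in this assay, though this rests on a single step. No measurement here speaks to the reason for this result.

The compounds shown carry only fluorinated phenyl groups on this nitrogen, so it remains open how a benzyl group, a cyclohexyl group or a phenyl ring bearing a carboxylic acid would read at the same place. As far as these compounds go, it also remains open whether any exchange at this position can produce a step beyond the scatter, in either direction, on the core of compound 1.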